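Amide tail exchange in a cytotoxicity series

This account rests on a few compounds, and the source may have more. Where it says the series, first, only, none or still open, it means among the compounds named here.

Measured so far in a functional assay on HT-29 cells (Homo sapiens) for cytotoxicity, read by MTT assay, with a stated time of 24 h, tested at 6.4 ug/mL; a higher number here means a stronger effect of the compound at the concentration tested, a lower number a weaker effect:
Compound 1 `Cn1c(-c2ccc(NC(=O)CSc3nc4ccccc4s3)cc2)nc(-c2ccccc2)c1-c1ccccc1` gives 36.8%.
Compound 2 `Cn1c(-c2ccc(NC(=O)CSC3=NCCS3)cc2)nc(-c2ccccc2)c1-c1ccccc1` gives 31%.

Compound 2 stands lowest of the two numbers; its nearest is compound 1, and the step of a number 5.8 percentage points lower from compound 1 to compound 2 (within the scatter) lies within the scatter, so no order between them is claimed. Compound 3 `CN1CCN(CC(=O)Nc2ccc(-c3nc(-c4ccccc4)c(-c4ccccc4)n3C)cc2)CC1` differs from compound 2 by a group of 7 heavy atoms (5 carbon, 2 nitrogen; one six-membered non-aromatic ring with 2 hetero atoms) in place of a group of 6 heavy atoms (3 carbon, 1 nitrogen, 2 sulfur; one five-membered non-aromatic ring with 2 hetero atoms), on a saturated chain carbon bound to a carbonyl carbon. Among the measured compounds shown here, only the step from compound 1 to compound 2 bears on this, and it was small; it exchanged groups on a sulfur, whereas here the exchange sits elsewhere and no measured step covers it. The expected step is therefore a number 1 percentage points lower from compound 2 to compound 3 (within the scatter), nothing beyond the scatter. Compound 3 is estimated at 30%, with a range from 15% to 45%.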

Compound 3, a percentage reported as activity, at one concentration (the size of the read-out at that concentration, not a potency): 28.8%
Compound 3: the middle estimate sits 1.2 percentage points above what was measured, within the range that was stated.
By their numbers in this assay, from the lowest: compounds 3, 2 and 1 (each within the scatter of the next).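

On the saturated chain carbon bound to a carbonyl carbon, 4-methylpiperazin-1-yl now replaces both sulfur-linked tails, and this assay shows a number 2.2 percentage points lower from compound 2 to compound 3 (within the scatter) and a number 8 percentage points lower from compound 1 to compound 3 (within the scatter) for this exchange. The position thus tolerates a tail without sulfur, joined through a ring nitrogen, with no change that can be read in this series. Nothing available explains this reading.

On these data alone, whether a carboxylic acid, a primary amine or a morpholine on the same carbon would give a step beyond the scatter remains open. Also open, as far as these compounds go, is how these compounds compare at other concentrations.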